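A few compounds are considered here, and "the series" means these few. Any claim that something is new, unique, unknown or untested is made for them only; others in the source may bear on it.

Working notes on the series.

The parent, compound 1 `COC(=O)[C@@]1(C)CCC=C2[C@@H]1CC[C@@H](C)[C@]2(C)Cc1c[nH]c2ccccc12`, is the least substituted member: in a functional assay on WiDr cells (Homo sapiens) for inhibition, read by sulforhodamine B assay, with a stated time of 48 h (on this read-out higher numbers stand for weaker inhibition of growth and lower numbers for stronger inhibition of growth), compound 1 gives 8700 nM. Compound 2 `COC(=O)[C@@]1(C)CCC=C2[C@@H]1CC[C@@H](C)[C@]2(C)Cc1c[nH]c2c(C)cccc12` carries a methyl on the aromatic carbon, and in this assay compound 2 gives 26000 nM; the move a 3.0-fold higher number from compound 1 to compound 2 (0.48 log units; beyond the scatter). Compound 3 `COC(=O)[C@@]1(C)CCC=C2[C@@H]1CC[C@@H](C)[C@]2(C)Cc1c[nH]c2c(Br)cccc12` carries a bromo at the same place, and in this assay compound 3 gives 32000 nM. Against compound 1 the move a 3.7-fold higher number from compound 1 to compound 3 (0.57 log units; beyond the scatter), while against compound 2 the move a 1.2-fold higher number from compound 2 to compound 3 (0.09 log units; within the scatter), so compound 3 holds the highest number of the three, though its gap to compound 2 is within the scatter.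

Compound 4 `COC(=O)[C@@]1(C)CCC=C2[C@@H]1CC[C@@H](C)[C@]2(C)Cc1c[nH]c2c(Cl)cccc12` is the next step: chloro in place of bromo on an aromatic carbon. Among the measured compounds shown here, no measured pair exchanges one halogen for another; the nearest guide is the bromo-for-methyl exchange, a 1.2-fold higher number from compound 2 to compound 3 (0.09 log units; within the scatter), which barely moved the number, together with the two modest rises from compound 1 to its substituted analogues. Taken together these suggest that a small group at this position gives a number near that of compound 3, with no step beyond the scatter expected.

Compound 4 is therefore expected to give about 30000 nM in this assay, with a range from 14000 nM to 65000 nM, an expected step of a 1.1-fold lower number from compound 3 to compound 4 (0.03 log units; within the scatter).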

Compound 4, concentration for 50% growth inhibition: 31000 nM
The estimate for compound 4 lay 1.0-fold (0.01 log units) below the measured number; the range from low to high includes it.
By their numbers in this assay, from the lowest: compound 1; then compounds 2, 4 and 3 (each within the scatter of the next).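

In this assay, chloro in place of bromo gives a 1.0-fold lower number from compound 3 to compound 4 (0.01 log units; within the scatter), and chloro in place of methyl gives a 1.2-fold higher number from compound 2 to compound 4 (0.08 log units; within the scatter), so this position now has a direct exchange of one halogen for another, and compound 2, compound 3 and compound 4 cannot be told apart by this read-out. Against the unsubstituted parent, chloro gives a 3.6-fold higher number from compound 1 to compound 4 (0.55 log units; beyond the scatter), beyond the scatter, so all three groups at this place on the aromatic ring, methyl, bromo and chloro, share a modest loss of growth inhibition relative to compound 1, with no compound among the three going against it. No measurement is available here that would explain why these three groups cannot be told apart.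

The compounds shown leave open whether the same loss would appear with a group of another kind at this place, such as a hydroxyl, an amine or a methoxy group. They also leave open whether a chloro elsewhere on the six-membered aromatic ring, or a carboxylic acid in place of the methyl ester on the shared core, would give a number nearer to that of compound 1.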